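Morpholine-to-piperidine swap on the dithiocarbamate of compound 1

The compounds below may be only part of what the source reports. "The series", "measured", "known", "first", "only" and "open" are said of these compounds alone.

Working notes on a small chromone-derived set tested in a functional assay on LM7 cells (Homo sapiens) for antiproliferative activity, read by MTT assay, with a stated time of 72 h; a lower number here means a stronger inhibitor, a higher number a weaker inhibitor. Among the measured compounds shown here, compound 1 `COc1ccc2oc(CSC(=S)N3CCOCC3)cc(=O)c2c1` gives 11000 nM in this assay and is the only member with a numerical value. Compound 2 `COc1ccc2occ(CSC(=S)N3CCOCC3)c(=O)c2c1` returns only a limit, > 40000 nM, so its potency is not fixed by a number. The limit is recorded as the limit of > 40000 nM in this assay, at which 1 of the 2 values shown sits. For the measured compounds named here, no pair of measured compounds differs in a single place, so no measured step is available.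

Compound 3 `COc1ccc2oc(CSC(=S)N3CCCCC3)cc(=O)c2c1` has not been tested. Relative to compound 1 the change is piperidin-1-yl in place of morpholin-4-yl on a thiocarbonyl carbon. With no measured step of this kind in the set, the expectation is a step from compound 1 to compound 3 of a 1.2-fold lower number from compound 1 to compound 3 (0.09 log units; within the scatter), essentially none beyond the scatter. Compound 3 is therefore estimated at 9000 nM in this assay, within 3000 nM to 30000 nM.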

Compound 3, half-maximal inhibitory concentration: 5000 nM
Estimate against measurement, compound 3: 1.8-fold (0.26 log units) above; measured number inside the range.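

In this assay, the group on the thiocarbonyl carbon now has its first measured step: a 2.2-fold lower number from compound 1 to compound 3 (0.34 log units; beyond the scatter). This shows that the position is not indifferent to the ring placed there, as piperidin-1-yl in place of morpholin-4-yl keeps a six-membered non-aromatic ring and still gives a modest step beyond the scatter. Nothing measured here bears on the cause of this step.

Going by these compounds, it remains open whether the trend extends to other amines at this place, such as piperazin-1-yl or an open-chain diethylamino group. On these data alone, it is also open whether the same swap would have any effect on the core of compound 2, for which only a limit is available.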